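The source may report more compounds than this note shows. Statements on the series, on what has been measured and on what is new or still open speak of the compounds shown alone.

Measured compounds:
- compound 1 `CCCOC(=O)C1=C(C)NC(=O)NC1c1ccoc1`: 50%
- compound 2 `CCCC(=O)C1=C(C)NC(=O)NC1c1ccoc1`: 1%
- compound 3 `CC1=C(C(N)=O)C(c2ccoc2)NC(=O)N1`: 1%

In an assay on membranes from CHO cells for displacement of a labelled ligand from adenosine receptor A1 (Homo sapiens), read by scintillation counting, with a stated time of 60 min, tested at 1 uM (a higher number here means more inhibition at the concentration tested (going by the name of the read-out), a lower number less inhibition), compound 3 sits level with compound 2 at the digits shown, and together they are the lowest of the three numbers; compound 1 stands furthest from compound 3, at a value higher by a number 49 percentage points lower from compound 1 to compound 3 (beyond the scatter). Compound 4 `CC1=C(C(=O)OC2CCC2)C(c2ccoc2)NC(=O)N1` differs from compound 3 by cyclobutyloxy in place of amino on a carbonyl carbon. The step bearing on this is the one running the other way, where the amino-for-propoxy swap gave a number 49 percentage points lower from compound 1 to compound 3 (beyond the scatter); the propyl-for-propoxy swap gave a matching drop of a number 49 percentage points lower from compound 1 to compound 2 (beyond the scatter), while no change at the digits printed from compound 2 to compound 3 (within the scatter) separates compounds 2 and 3. Returning an alkoxy group to this carbonyl carbon is therefore expected to bring a large rise in this assay, about a number 44 percentage points higher from compound 3 to compound 4 (beyond the scatter). Compound 4 is thus estimated at 45%, within a range of 20% to 70%.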

Compound 4, a percentage reported as inhibition, at one concentration (the size of the read-out at that concentration, not a potency): 20%
The estimate for compound 4 lay 25 percentage points above the measured number; measured number inside the range.
By their numbers in this assay, from the lowest: compounds 2 and 3 (each within the scatter of the next); then compound 4; then compound 1.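

In this assay, cyclobutyloxy on this carbonyl carbon gives a number 19 percentage points higher from compound 3 to compound 4 (beyond the scatter) in place of amino, and a number 19 percentage points higher from compound 2 to compound 4 (beyond the scatter) in place of propyl. The group on the oxygen also counts, since cyclobutyl in place of propyl gives a number 30 percentage points lower from compound 1 to compound 4 (beyond the scatter), so an alkoxy group does not by itself restore the number seen with propoxy. From the compounds shown here alone, whether an ethoxy, a butoxy or a cyclopentyloxy group would come closer to compound 1 stays open. Nothing shown gives a cause for the difference between propoxy and cyclobutyloxy.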